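A few compounds are considered here, and "the series" means these few. Any claim that something is new, unique, unknown or untested is made for them only; others in the source may bear on it.

Measured in a functional assay on MCF7 cells (Homo sapiens) for antiproliferative activity, read by MTT assay, with a stated time of 72 h; a lower number here means a stronger inhibitor, a higher number a weaker inhibitor:
Compound 1 `COCn1c(CC(COCc2ccccc2)COCc2ccccc2)cc(=O)[nH]c1=O`: > 100000 nM
Compound 2 `COCn1c(CC(COCc2ccccc2)COCc2ccccc2)c(C)c(=O)[nH]c1=O`: 72600 nM
Compound 3 `O=c1cc(CC(O)COCc2ccccc2)[nH]c(=O)[nH]1`: > 100000 nM

The value of compound 1 is a limit of the assay, not a number. The value of compound 3 is likewise a limit.

From compound 1 to compound 2 the change is methyl in place of hydrogen on an aromatic carbon. The step is an at least 1.3-fold lower number from compound 1 to compound 2 (0.13 log units; that floor lies within the scatter); its floor rests on (the limit of > 100000 nM in this assay, at which 2 of the 3 values shown sit), so its true size is not known.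

Compound 4 `Cc1c(CC(O)COCc2ccccc2)[nH]c(=O)[nH]c1=O` is not yet measured. The difference between the core of compound 3 and the core of compound 1 is not broken down here. The change from compound 3 to compound 4 is methyl in place of hydrogen on an aromatic carbon. The surroundings of the place are not identical: in the pair compound 1 to compound 2 the place is also meta to a methoxymethyl group (3 heavy atoms), which is absent in compound 3, so this is the same kind of change rather than the same change.

The step expected from compound 3 to compound 4 in this assay is an at least 1.0-fold lower number from compound 3 to compound 4 (0.02 log units; that floor lies within the scatter), set beside the earlier step of an at least 1.3-fold lower number from compound 1 to compound 2 (0.13 log units; that floor lies within the scatter), whose floor is small and whose size is bounded only by the limit of > 100000 nM in this assay, at which 2 of the 3 values shown sit. Compound 4 is estimated at 95000 nM, between 40000 nM and 200000 nM, with a real chance that only a limit is reported.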

Compound 4, half-maximal inhibitory concentration: > 100000 nM
Compound 4: only a limit was reported; the forecaster's own chance of this, stated with the estimate: 60%; middle value at least 1.0-fold (0.02 log units) away from the limit.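

Compound 3 and compound 4 both stand at a limit in this assay, so no step can be read between them for methyl in place of hydrogen on an aromatic carbon: the limit of > 100000 nM in this assay, at which 3 of the 4 values shown sit.

The compounds shown leave open whether this methyl changes the number at all on the core of compound 3.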